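Dimethoxy pattern on the sulfonyl aryl of the shared core

The source may hold more compounds than are shown below. What is called first, only, known or untested is meant among the compounds shown, and "the series" means these compounds.

Measured so far in a functional assay on SMMC-7721 cells (Homo sapiens) for antiproliferative activity, read by MTT assay, with a stated time of 72 h; on this read-out higher numbers stand for weaker inhibition and lower numbers for stronger inhibition:
compound 1 `CN(c1ccc2[nH]c(-c3n[nH]c4ccccc34)cc2n1)S(=O)(=O)c1ccccc1` gives 12000 nM
compound 2 `COc1ccc(S(=O)(=O)N(C)c2ccc3[nH]c(-c4n[nH]c5ccccc45)cc3n2)cc1OC` gives 26600 nM
compound 3 `COc1ccc(OC)c(S(=O)(=O)N(C)c2ccc3[nH]c(-c4n[nH]c5ccccc45)cc3n2)c1` gives 4280 nM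

Compound 3 stands lowest of the three numbers in this assay, with compound 1 nearest and compound 2 furthest. The next compound, compound 4 `COc1ccc(S(=O)(=O)N(C)c2ccc3[nH]c(-c4n[nH]c5ccccc45)cc3n2)c(OC)c1`, differs from compound 3 by 2,4-dimethoxyphenyl in place of 2,5-dimethoxyphenyl on a sulfonyl sulfur. Within the data shown here, no measured step covers this exact rearrangement. The related steps show how much the methoxy placement matters: a 2.2-fold higher number from compound 1 to compound 2 (0.35 log units; beyond the scatter), a 2.8-fold lower number from compound 1 to compound 3 (0.45 log units; beyond the scatter) and a 6.2-fold lower number from compound 2 to compound 3 (0.79 log units; beyond the scatter), all modest and all beyond the scatter. Compound 4 shares one methoxy position with compound 3 and one with compound 2, so a modest upward step toward the values of compound 1 and compound 2 is expected, a 2.1-fold higher number from compound 3 to compound 4 (0.32 log units; beyond the scatter). The estimate for compound 4 in this assay is 9000 nM, within 3000 nM to 27000 nM.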

Compound 4, half-maximal inhibitory concentration: 10800 nM
Compound 4: middle estimate off by 1.2-fold (0.08 log units), on the low side; the measured number falls inside the stated range.
By their numbers in this assay, from the lowest: compound 3; then compounds 4 and 1 (each within the scatter of the next); then compound 2.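

In this assay, rearranging the same two methoxy groups is enough to move the number: 2,4-dimethoxyphenyl in place of 2,5-dimethoxyphenyl on the sulfonyl sulfur gives a 2.5-fold higher number from compound 3 to compound 4 (0.40 log units; beyond the scatter) and in place of 3,4-dimethoxyphenyl gives a 2.5-fold lower number from compound 2 to compound 4 (0.39 log units; beyond the scatter) in the same read-out. Compound 4 thus falls between the other two dimethoxy isomers. Against phenyl, the step is a 1.1-fold lower number from compound 1 to compound 4 (0.05 log units; within the scatter) and so, unlike the other two patterns, this one does not separate from phenyl.

Open, from the compounds shown here alone, is how a single methoxy or an amine on this aryl would compare. No evidence here explains the differences among the isomers.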